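A few compounds are considered here, and "the series" means these few. Any claim that something is new, unique, unknown or untested is made for them only; others in the source may bear on it.

Measured compounds:
- compound 1 `CC(C)(C)c1cc(NC(=O)Nc2ccc(-c3cn4ccccc4n3)cc2)no1` — 3.09 nM
- compound 2 `CC(C)(C)c1cc(NC(=O)Nc2ccc(-c3nc4ccccc4s3)cc2)no1` — 172 nM
- compound 3 `CC(C)(C)c1cc(NC(=O)Nc2ccc(-c3cn4cccc(Cl)c4n3)cc2)no1` — 353 nM

In a functional assay on MV4-11 cells (Homo sapiens) for cytotoxicity, read by MTT assay, with a stated time of 72 h (a higher number here means a weaker inhibitor, a lower number a stronger inhibitor), compound 1 gives the lowest of the three numbers; its nearest neighbour is compound 2, reached by a 56-fold higher number from compound 1 to compound 2 (1.75 log units; beyond the scatter), and the furthest is compound 3, reached by a 110-fold higher number from compound 1 to compound 3 (2.06 log units; beyond the scatter). Both steps lie beyond the scatter, so compound 1 is the most potent of the measured set.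

Compound 4 `CC(C)(C)c1cc(NC(=O)Nc2ccc(-c3cn4cc(Cl)ccc4n3)cc2)no1` is compound 1 with chloro in place of hydrogen on an aromatic carbon, two atoms from the ring nitrogen, meta to a fused ring and para to a fused ring. The step that bears on it is a 110-fold higher number from compound 1 to compound 3 (2.06 log units; beyond the scatter), which is also a chloro in place of hydrogen on the same ring, though at a different carbon. The step from compound 1 to compound 2 shows that this part of the molecule tolerates change poorly. Going by the values given here, a clear loss in this assay is therefore expected for compound 4, of about a 23-fold higher number from compound 1 to compound 4 (1.36 log units; beyond the scatter), with wide uncertainty because the only comparable step is a 110-fold higher number from compound 1 to compound 3 (2.06 log units; beyond the scatter) at another position. Compound 4 is estimated at 70 nM, in the range 10 nM to 500 nM.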

Compound 4, half-maximal inhibitory concentration: 24.8 nM
The estimate for compound 4 lay 2.8-fold (0.45 log units) above the measured number; the range from low to high includes it.
By their numbers in this assay, from the lowest: compound 1; then compound 4; then compound 2; then compound 3.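

Chloro in place of hydrogen at this carbon, two atoms from the ring nitrogen, gives in this assay a modest loss, an 8.0-fold higher number from compound 1 to compound 4 (0.90 log units; beyond the scatter), so the position does not take this change without cost, though the cost is limited. Compound 4 at 24.8 nM has a clearly lower number than compound 3 at 353 nM, which carries the same chloro at a different carbon of that ring, so the size of the loss depends on where the chloro stands. No measurement at hand accounts for the difference between the two chloro positions.

Chloro is the only group shown at this carbon, so it stays open whether fluoro, methyl or an amine there would cost more or less. From the compounds shown here alone, the remaining carbons of that ring also stay open.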